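This account rests on a few compounds, and the source may have more. Where it says the series, first, only, none or still open, it means among the compounds named here.

Measured in a functional assay on HEK293 cells for antagonist activity at transient receptor potential cation channel subfamily M member 8 (Rattus norvegicus), read by calcium flux; a lower number here means a stronger inhibitor, a higher number a weaker inhibitor:
compound 1 `Cc1ccc(C(=O)N[C@@H]2C[C@H](C)CC[C@H]2C(C)C)cc1`: 2200 nM
compound 2 `CCCCCCCC/C=C\CCCCCCCCC(=O)N[C@@H]1C[C@H](C)CC[C@H]1C(C)C`: 60600 nM

Compound 1 holds the lowest of the two numbers; compound 2 sits at a far higher number, beyond the scatter. Compound 3 `CC(C)[C@@H]1CC[C@@H](C)C[C@H]1NC(=O)c1ccc(-c2ccccc2)cc1` keeps the shared core of compound 1 and differs in one place: phenyl in place of methyl on an aromatic carbon. No such change has been measured in this series, so its effect is uncertain. A modest move toward a lower number, at the edge of the scatter, is expected, so that the step of a 2.2-fold lower number from compound 1 to compound 3 (0.34 log units; beyond the scatter) is estimated to be small. Compound 3 is therefore expected to give about 1000 nM in this assay, within 300 nM to 4000 nM.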

Compound 3, half-maximal inhibitory concentration: 20 nM
Beside the measured number, compound 3's estimate is 50-fold (1.70 log units) above it; the measured number lies below the stated range.
By their numbers in this assay, from the lowest: compound 3; then compound 1; then compound 2.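

In this assay the change from methyl to phenyl on an aromatic carbon, para to a large group, gives a 110-fold lower number from compound 1 to compound 3 (2.04 log units; beyond the scatter) and counts as a large step. The earlier compounds shown here could not show that this one position can move the number so strongly, or that a second aromatic ring is accepted there. No available evidence bears on why the phenyl has this effect.
Going by these compounds, whether a smaller group such as methoxy or a pyridine ring would act in the same way remains open. A single change at this position cannot establish a trend.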